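Replacing diethylamino with 1H-imidazol-1-yl in compound 3

A few compounds are considered here, and "the series" means these few. Any claim that something is new, unique, unknown or untested is made for them only; others in the source may bear on it.

Results so far in a functional assay on SMMC-7721 cells (Homo sapiens) for cytotoxicity, read by MTT assay, with a stated time of 48 h; on this read-out higher numbers stand for weaker inhibition and lower numbers for stronger inhibition

Compound 1 `Cc1ccc2c(=O)cc(-c3ccc(N)cc3)oc2c1` - "not determined" (no result reported)
Compound 2 `CCN(CC)Cc1cc(Cl)cc2c(=O)cc(-c3ccc([N+](=O)[O-])cc3)oc12` - 2990 nM
Compound 3 `CCN(CC)Cc1cc(Cl)cc2c(=O)cc(-c3ccccc3Cl)oc12` - 810 nM

Of the two numbers in this assay the lower belongs to compound 3 at 810 nM and compound 1 offers no number for comparison. The next compound is compound 4 `O=c1cc(-c2ccccc2Cl)oc2c(Cn3ccnc3)cc(Cl)cc12` which differs from compound 3 in one place. The change is 1H-imidazol-1-yl in place of diethylamino on a saturated chain carbon bound to an aromatic carbon and it turns (diethylamino)methyl into (1H-imidazol-1-yl)methyl.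

Within the data shown here, only one measured step is available. It is a 3.7-fold lower number from compound 2 to compound 3 (0.57 log units; beyond the scatter) and it is modest, though beyond the scatter. That step exchanges 4-nitrophenyl for 2-chlorophenyl, so it gives only a rough idea of size and says nothing directly about the present change. Among the measured compounds shown here, no measured pair shows what replacing diethylamino does, which leaves the direction open. Compound 3 already holds the lower of the two numbers, so a move to a higher number, meaning weaker inhibition, is the more likely guess. The expected step is a 1.9-fold higher number from compound 3 to compound 4 (0.27 log units; within the scatter) and it is of similarly modest size. For compound 4 the estimate is 1500 nM with an expected range from 400 nM to 6000 nM when it is measured.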

Compound 4, half-maximal inhibitory concentration: 1070 nM
The estimate for compound 4 lay 1.4-fold (0.15 log units) above the measured number, within the range that was stated.
By their numbers in this assay, from the lowest: compounds 3 and 4 (each within the scatter of the next); then compound 2.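

In this assay, the exchange of diethylamino for 1H-imidazol-1-yl on a saturated chain carbon bound to an aromatic carbon gives a 1.3-fold higher number from compound 3 to compound 4 (0.12 log units; within the scatter), so this read-out does not separate the two compounds. Among these compounds, this is the first measured pair that varies this group rather than the aryl substituent, and it shows that an open-chain diethylamino group and a five-membered aromatic ring with 2 hetero atoms, each of 5 heavy atoms, can occupy this place with no difference beyond the scatter. No supporting measurement bears on why the two groups read alike, so the result stands here as an observation without an explanation.

The compounds shown leave open whether an amine at this place matters at all, since a plain methyl group, a morpholine or piperidine ring, or a longer chain between the core and the imidazole could each test how far the tolerance seen here extends. They also leave open whether the same exchange would read alike with the 4-nitrophenyl group of compound 2 in place of the 2-chlorophenyl group.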